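The source may hold more compounds than are shown below. What is called first, only, known or untested is meant among the compounds shown, and "the series" means these compounds.

In a functional assay on MCF7 cells (Homo sapiens) for antiproliferative activity, read by MTT assay, with a stated time of 72 h (a lower number here means a stronger inhibitor, a higher number a weaker inhibitor), compound 1, whose structure is `COc1ncc(-c2ccc3c(c2)N(c2ccc(C)cc2)C(=O)CO3)cc1NS(=O)(=O)c1ccc(F)cc1`, gives 15400 nM. Compound 2, with structure `COc1ncc(-c2ccc3c(c2)N(c2ccc(F)cc2)C(=O)CO3)cc1NS(=O)(=O)c1ccc(F)cc1`, differs from it by a single change: fluoro in place of methyl on an aromatic carbon. For compound 2 the result in this assay is a limit of the assay rather than a number, > 40000 nM. That change made an at least 2.5-fold higher number from compound 1 to compound 2 (0.41 log units; beyond the scatter). Compound 3, whose structure is `Cc1ccc(N2C(=O)COc3ccc(-c4cccc(NS(=O)(=O)c5ccc(F)cc5)c4)cc32)cc1`, is built on a different core; how its core differs from that of compound 1 is not broken down here. In this assay compound 3 gives 32100 nM, a higher number than compound 1 shows. Compound 4, with structure `O=C1COc2ccc(-c3cccc(NS(=O)(=O)c4ccc(F)cc4)c3)cc2N1c1ccc(F)cc1`, carries the same change on the core of compound 3: fluoro in place of methyl on an aromatic carbon. The step from compound 3 to compound 4 in this assay is expected to be a 2.3-fold higher number from compound 3 to compound 4 (0.37 log units; beyond the scatter), resting on the step of an at least 2.5-fold higher number from compound 1 to compound 2 (0.41 log units; beyond the scatter) and on (the limit of > 40000 nM in this assay, at which 1 of the 3 values shown sits), which compound 2 already reached. Compound 4 is therefore expected to give about 75000 nM, with a likely span from 35000 nM to 200000 nM, and a good chance that only a limit is reported.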

Compound 4, half-maximal inhibitory concentration: > 40000 nM
Compound 4 ended at the assay's limit; the forecaster's own chance of this, stated with the estimate: 70%; the middle value does not contradict the limit.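

In this assay compound 4 gives > 40000 nM, which is a limit of the assay and not a number. Putting fluoro in place of methyl on the core of compound 3 therefore makes an at least 1.2-fold higher number from compound 3 to compound 4 (0.09 log units; that floor lies within the scatter), so this step alone does not establish a real loss of activity on this core. The result fits the change carrying over from one core to the other, since nothing here points the opposite way, but it does not show that the change has the same size on both cores: the same change on two cores in this assay, an at least 2.5-fold higher number (0.41 log units; beyond the scatter) from compound 1 to compound 2 and an at least 1.2-fold higher number (0.09 log units; that floor lies within the scatter) from compound 3 to compound 4; the limit leaves it open whether they differ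

On these data alone, with compound 2 and compound 4 both reported only as limits, the true size of each step stays open: the limit of > 40000 nM in this assay, at which 2 of the 4 values shown sit. Also open is what a chloro, a methoxy or an amine would do in place of the methyl of the 4-methylphenyl group, and whether any such group would give a number on both cores that could be compared directly.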